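Swapping the end group of compound 2

A few compounds are considered here, and "the series" means these few. Any claim that something is new, unique, unknown or untested is made for them only; others in the source may bear on it.

Compound 1 `CN(C)C1CCN(C(=O)CCCOc2cc(C(=O)N3CCCCc4sccc43)ccc2NC(=O)c2ccccc2-c2ccccc2)CC1`: 0.005 mg/kg
Compound 2 `CN1CCN(C(=O)CCCOc2cc(C(=O)N3CCCCc4sccc43)ccc2NC(=O)c2ccccc2-c2ccccc2)CC1`: 0.03 mg/kg
Compound 3 `O=C(Nc1ccc(C(=O)N2CCCCc3sccc32)cc1O)c1ccccc1-c1ccccc1`: 0.04 mg/kg

In a functional assay on the whole organism for antagonist activity, with Rattus norvegicus as the target (a higher number here means that more compound is needed for the effect, a lower number that less compound is needed), compound 2 gives 0.03 mg/kg, and it has one close neighbour and one distant one among the three numbers. The close one is a 1.3-fold higher number from compound 2 to compound 3 (0.12 log units; within the scatter), a step within the scatter. The distant one is a 6.0-fold higher number from compound 1 to compound 2 (0.78 log units; beyond the scatter), a step beyond the scatter.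

Compound 4 `O=C(Nc1ccc(C(=O)N2CCCCc3sccc32)cc1OCCCC(=O)N1CCC(N2CCCCC2)CC1)c1ccccc1-c1ccccc1` keeps everything in compound 2 except one group, with 4-(piperidin-1-yl)piperidin-1-yl in place of 4-methylpiperazin-1-yl on a carbonyl carbon.

Among the measured compounds shown here, the best guide is a 6.0-fold higher number from compound 1 to compound 2 (0.78 log units; beyond the scatter), the only measured step at this same carbonyl carbon. Read backwards, it says that a change away from 4-methylpiperazin-1-yl can lower the number. The group in compound 1, 4-(dimethylamino)piperidin-1-yl, resembles the entering group in having a piperidin-1-yl ring with a nitrogen-bearing group on it, and compound 1 reaches 0.005 mg/kg. The other step, a 1.3-fold higher number from compound 2 to compound 3 (0.12 log units; within the scatter), removes the whole chain and stays within the scatter, so this end of the molecule need not always matter. The expected step is a 3.0-fold lower number from compound 2 to compound 4 (0.48 log units; beyond the scatter), an estimate that points to a lower number, though less far than compound 1 reaches. For compound 4 the estimated value is 0.01 mg/kg, with an expected range from 0.003 mg/kg to 0.04 mg/kg.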

Compound 4, dose for 50% inhibition: 0.03 mg/kg
For compound 4 the middle estimate is 3.0-fold (0.48 log units) below the measured one, within the range that was stated.
By their numbers in this assay, from the lowest: compound 1; then compounds 2, 4 and 3 (each within the scatter of the next).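

In this assay, 4-(piperidin-1-yl)piperidin-1-yl in place of 4-methylpiperazin-1-yl gives no change at the digits printed from compound 2 to compound 4 (within the scatter), so a larger group with a second ring on this carbonyl carbon does not by itself lower the number. Having a piperidin-1-yl ring on the carbonyl carbon is not enough to reach the value of compound 1, 0.005 mg/kg: keeping that ring while changing only the group on a saturated ring carbon gives a 6.0-fold higher number from compound 1 to compound 4 (0.78 log units; beyond the scatter), which locates this difference at the outer amine, dimethylamino in one compound and piperidin-1-yl in the other. Nothing measured here accounts for the gap between these two amines.

The compounds shown leave open whether dimethylamino is special on that ring carbon or whether other small amines, such as methylamino, pyrrolidin-1-yl or an unsubstituted amine, would read the same way. They also leave open how a carboxylic acid at that ring carbon, or a longer chain carrying 4-(dimethylamino)piperidin-1-yl, would compare with compound 1.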